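The source may report more compounds than this note shows. Statements on the series, on what has been measured and on what is new or still open speak of the compounds shown alone.

Compound 2, `Cc1cc(CN2C(=O)C(C3=CS(=O)(=O)c4cc(NS(C)(=O)=O)ccc4N3)=C(O)[C@@H]2C(C)(C)C)ccc1F`, was tested in an ADME assay on 2209-23 cells (Homo sapiens) for cytotoxicity, read by WST assay and thymidine incorporation (on this read-out lower numbers stand for higher toxicity in this test and higher numbers for lower toxicity in this test), and gave > 50000 nM, which is a limit of the assay rather than a number. Compound 1, `CC(C)(C)[C@H]1C(O)=C(C2=CS(=O)(=O)c3cc(NS(C)(=O)=O)cc(F)c3N2)C(=O)N1Cc1ccc(F)cc1`, also reached only a limit in this assay with > 50000 nM. Compound 3, `CC(C)(C)[C@H]1C(O)=C(C2=CS(=O)(=O)c3cc(F)ccc3N2)C(=O)N1Cc1ccc(F)cc1`, likewise sits at a limit in this assay with > 50000 nM. Compound 2 therefore cannot be placed above or below its companions; all that the numbers show is the limit of > 50000 nM in this assay, at which 3 of the 3 values shown sit. Among the measured compounds shown here, no step between measured compounds can be computed from such values.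

Compound 4, `CC(C)(C)[C@H]1C(O)=C(C2=CS(=O)(=O)c3cc(NS(C)(=O)=O)ccc3N2)C(=O)N1Cc1ccc(F)cc1F`, differs from compound 2 by 2,4-difluorophenyl in place of 4-fluoro-3-methylphenyl on a saturated chain carbon bound to an amide-type nitrogen in a ring. Because compound 1, compound 2 and compound 3 all sit at the limit of > 50000 nM in this assay, at which 3 of the 3 values shown sit, no step beyond the usual scatter is expected in this assay, in either direction. Compound 4 is expected to give 60000 nM in this assay, within a range from 30000 nM to 150000 nM, and most probably once more only as a limit. This amounts to an expected step that the limit leaves unreadable from compound 2 to compound 4.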

Compound 4, half-maximal cytotoxic concentration: > 50000 nM
Compound 4 ended at the assay's limit; the forecaster's own chance of this, stated with the estimate: 85%; the middle value lies beyond the limit too.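

No step can be read between compound 2 and compound 4 in this assay, as both results are limits of the assay and not numbers: the limit of > 50000 nM in this assay, at which 4 of the 4 values shown sit.

The compounds shown leave open at what concentration any of them turns cytotoxic, and whether 2,4-difluorobenzyl in place of 4-fluoro-3-methylbenzyl alters that concentration.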